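The compounds below may be only part of what the source reports. "The series", "measured", "known", "first", "only" and "open" are said of these compounds alone.

Compound 1 `CC(C)(C)c1ccc(C(=O)NCc2ccc(OC(F)(F)F)cc2)cc1` is the weakest of the three measured compounds in an assay on HeLa cells with Bile acid receptor (Homo sapiens) as the target, read by a luciferase reporter, with a stated time of 24 h (a higher number here means that more compound is needed for the effect, a lower number that less compound is needed), where it gives 160 nM. Its nearest neighbour on the numbers is compound 3 `CC(C)(C)c1ccc(C(=O)NCc2ccc(C(=O)O)c(Cl)c2)cc1`, which in this assay gives 8.8 nM, a step beyond the scatter; the furthest is compound 2 `CC(C)(C)c1ccc(C(=O)NCc2ccc(C(=O)O)cc2F)cc1`, which gives 7.8 nM, likewise beyond the scatter. Going by the values given here, no single-site step between measured compounds is available, so the account turns on one change from compound 1: in compound 4 `CN(C)C(=O)c1ccc(CNC(=O)c2ccc(C(C)(C)C)cc2)cc1` the difference is dimethylcarbamoyl in place of trifluoromethoxy on an aromatic carbon. The group that enters keeps the same count of heavy atoms and acceptors as the one that leaves. Among the compounds with values here, the only measured comparison, compound 1 at 160 nM against compound 2 and compound 3, spans two places at once and cannot be read as a step for this single change. The expectation for compound 4 is therefore a modest move toward a lower number, within or barely beyond the scatter, as a 1.6-fold lower number from compound 1 to compound 4 (0.20 log units; within the scatter). Compound 4 is estimated at 100 nM, with a range from 25 nM to 600 nM.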

Compound 4, half-maximal effective concentration: 170 nM
Compound 4: middle estimate off by 1.7-fold (0.23 log units), on the low side; low and high end bracket the measured number.
By their numbers in this assay, from the lowest: compounds 2 and 3 (each within the scatter of the next); then compounds 1 and 4 (each within the scatter of the next).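

In this assay, dimethylcarbamoyl in place of trifluoromethoxy on an aromatic carbon, para to a large group, gives a 1.1-fold higher number from compound 1 to compound 4 (0.03 log units; within the scatter), so the assay does not tell these two groups apart at this place. Going by these compounds alone, this is the first step in the set that changes a single place, and it shows that on the shared core this position accepts a carbonyl-bearing group of the same heavy-atom count with no change beyond the scatter. Nothing measured here explains why the two groups read alike.

The compounds shown leave open how a carboxylic acid at this place would read without the fluorine or chlorine also carried by compound 2 and compound 3, whose change from compound 1 spans two places and cannot be read as a single step. They also leave open whether an amine or a primary amide here would depart from this flat step.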